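The compounds below may be only part of what the source reports. "The series", "measured", "known", "first", "only" and "open" are said of these compounds alone.

Measured so far in an assay on cells for inhibition of HSP60/HSP10 (Homo sapiens), with a stated time of 60 min; a higher number here means a weaker inhibitor, a lower number a stronger inhibitor:
- compound 1 `O=S(=O)(Nc1ccc2oc(-c3ccc(NS(=O)(=O)c4cccc5nonc45)cc3)nc2c1)c1ccc(Cl)s1`: 13000 nM
- compound 2 `O=S(=O)(Nc1ccc(-c2nc3ccccc3o2)cc1)c1ccccc1Cl`: > 100000 nM, a limit of the assay
- compound 3 `O=S(=O)(Nc1ccc2oc(-c3ccccc3)nc2c1)c1ccccc1F`: > 100000 nM, a limit of the assay

Only compound 1 returns a number in this assay. Compound 2 stands at a limit of the assay, not at a number, so its true value is known only as lying beyond it. Compound 3 likewise stands at a limit. Among the compounds with values here, both share (the limit of > 100000 nM in this assay, at which 2 of the 3 values shown sit), so the series so far offers no resolved step between two numbers, and no pattern of steps can be drawn from it.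

Compound 4 `O=S(=O)(Nc1ccc(-c2nc3ccccc3o2)cc1)c1ccc(Cl)c(Cl)c1` differs from compound 2 in one place: 3,4-dichlorophenyl in place of 2-chlorophenyl on a sulfonyl sulfur. Within the data shown here, no measured pair with this change exists in the set, so the size of the step is not known from the data. With compound 2 already at a limit, the expectation is that compound 4 will not move clearly beyond the scatter in either direction, and the step from compound 2 to compound 4 is expected to be a number no higher from compound 2 to compound 4 (the limit leaves the size open). Compound 4 is therefore estimated at 100000 nM in this assay, with a range from 30000 nM to 300000 nM, and most likely to be reported again only as a limit.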

Compound 4, half-maximal inhibitory concentration: 25000 nM
Compound 4: middle estimate off by 4.0-fold (0.60 log units), on the high side; the measured number lies below the stated range.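

In this assay, the group on the sulfonyl sulfur is a position that can shift the read-out with the rest of the molecule unchanged: 3,4-dichlorophenyl in place of 2-chlorophenyl gives an at least 4.0-fold lower number from compound 2 to compound 4 (0.60 log units; beyond the scatter). This change yields a resolved number, with compound 4 at 25000 nM, so this position now has a measured value to serve as a reference for further changes. The size of the step is only a lower bound, because compound 2 gives no number of its own: the limit of > 100000 nM in this assay, at which 2 of the 4 values shown sit.

The change alters both the number of chlorines and their placement on the phenyl ring, so the compounds shown do not tell whether the added chlorine or the new placement carries the step. Also open, going by these compounds, is how this position responds to a group other than chlorine, such as an amine or a carboxylic acid on the phenyl ring, and whether any such group would give a number lower than that of compound 4.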